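The source may hold more compounds than are shown below. What is called first, only, known or untested is meant among the compounds shown, and "the series" means these compounds.

The shared core is seen in compound 1, `O=C(c1cccc(Cl)c1)N1CCc2nc(C#Cc3ccccc3)sc2C1`, which carries a 3-chlorobenzoyl group on the ring amine and gives 8.7 nM in an assay on HEK293 cells for positive allosteric modulation of metabotropic glutamate receptor 5 (Homo sapiens), read by FLIPR, with a stated time of 1 h; a lower number here means that less compound is needed, a higher number that more compound is needed for the effect. Compound 2, `CC(C)S(=O)(=O)N1CCc2nc(C#Cc3ccccc3)sc2C1`, has an isopropylsulfonyl group at the same place. In this assay compound 2 reaches only the limit of > 10000 nM, so no number is known for it; it sits at the limit of > 10000 nM in this assay, at which 1 of the 2 values shown sits. Compound 3, `O=C(N1CCCC1)N1CCc2nc(C#Cc3ccccc3)sc2C1`, is not yet measured. It differs from compound 2 by (pyrrolidin-1-yl)carbonyl in place of isopropylsulfonyl on an amine nitrogen in a ring, bringing back a carbonyl on the ring amine as in compound 1 while the aromatic ring of compound 1 is replaced by a five-membered non-aromatic ring. The step is expected to move toward compound 1, so the estimate is a large gain, an at least 50-fold lower number from compound 2 to compound 3 (1.69 log units; beyond the scatter), beyond the usual scatter. Compound 3 is expected to give about 200 nM in this assay, with a range from 30 nM to 3000 nM.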

Compound 3, half-maximal effective concentration: 9.8 nM
The estimate for compound 3 lay 20-fold (1.31 log units) above the measured number; the measured number lies below the stated range.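

In this assay, pyrrolidin-1-yl in place of 3-chlorophenyl on a carbonyl carbon gives a 1.1-fold higher number from compound 1 to compound 3 (0.05 log units; within the scatter), so in this pair the carbonyl on the ring amine does not depend on an aromatic ring attached to it. Swapping the isopropylsulfonyl group for the (pyrrolidin-1-yl)carbonyl group gives an at least 1000-fold lower number from compound 2 to compound 3 (3.00 log units; beyond the scatter), which ties the large difference at this place to this exchange of groups. Compound 2 is known only through a limit of the assay, so the full size of that step stays open: the limit of > 10000 nM in this assay, at which 1 of the 3 values shown sits.

As far as these compounds go, whether a smaller ring, an open-chain dialkylamine or a methoxy group on the carbonyl fits as well as pyrrolidin-1-yl remains open. So does whether a sulfonyl group carrying a pyrrolidine or a phenyl ring would behave like the isopropylsulfonyl group.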